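Swapping one halogen for another on a shared core

The source may hold more compounds than are shown below. What is called first, only, known or untested is meant among the compounds shown, and "the series" means these compounds.

Of the compounds shown here, two have so far been measured in an assay on isolated protein for inhibition of Indoleamine 2,3-dioxygenase 1 (Homo sapiens), read by colorimetric assay, with stated times of 10 min and 30 min, tested at 100 uM; on this read-out higher numbers stand for more inhibition at the one concentration tested (going by the name of the read-out) and lower numbers for less inhibition. Compound 1 `Fc1ccccc1-c1c[nH]c(=S)s1` gives 29%. Compound 2 `S=c1[nH]c(-c2cccc(Br)c2)cs1` gives 81%, the higher of the two numbers, and its gap to compound 1 lies beyond the usual scatter. Compound 3 `S=c1[nH]c(-c2cccc(Cl)c2)cs1` differs from compound 2 by chloro in place of bromo on an aromatic carbon. For the measured compounds named here, no pair of measured compounds shows this swap, so the size of its effect is unknown here. Because compound 2 reaches 81%, compound 3 is expected to stay near it, with an estimated step of a number 9 percentage points lower from compound 2 to compound 3 (within the scatter) that may sit within the scatter. The estimate for compound 3 is 72%, between 50% and 88%.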

Compound 3, a percentage reported as inhibition, at one concentration (the size of the read-out at that concentration, not a potency): 40%
The estimate for compound 3 lay 32 percentage points above the measured number; measured number below the stated range.
By their numbers in this assay, from the lowest: compound 1; then compound 3; then compound 2.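

At this place on the six-membered aromatic ring, the choice of halogen matters: in this assay chloro in place of bromo gives a number 41 percentage points lower from compound 2 to compound 3 (beyond the scatter) for a change of a single heavy atom. For the compounds shown here, no earlier pair differed in one place, so this is the first measured effect of any single change on the shared core. Nothing available here accounts for this step.

From the compounds shown here alone, it remains open how iodo would compare with bromo on this aromatic carbon. An amine or a carboxylic acid at the same place is also unexplored here.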